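Removing the benzyl aryl group from a pyridone kinase inhibitor

The source may report more compounds than this note shows. Statements on the series, on what has been measured and on what is new or still open speak of the compounds shown alone.

Measured compounds:
compound 1 `O=c1ccc(-c2ccc3cn[nH]c3c2)cn1Cc1ccccc1F`, 37 nM
compound 2 `O=c1ccc(-c2ccc3cn[nH]c3c2)cn1Cc1ccccc1Cl`, 78 nM
compound 3 `Nc1cccc(Cn2cc(-c3ccc4cn[nH]c4c3)ccc2=O)c1`, 84 nM

In an assay for inhibition of MAP kinase-interacting serine/threonine-protein kinase 2 (Homo sapiens), read by luminescence and ADP-Glo, with a stated time of 2 h (a higher number here means a weaker inhibitor, a lower number a stronger inhibitor), compound 3 has the highest number of the three, close to compound 2 and separated from compound 1 by a 2.3-fold higher number from compound 1 to compound 3 (0.36 log units; beyond the scatter). Compound 4 `Cn1cc(-c2ccc3cn[nH]c3c2)ccc1=O` differs from compound 3 by hydrogen in place of 3-aminophenyl on a saturated chain carbon bound to an aromatic nitrogen. For the measured compounds named here, the measured steps of a 2.1-fold higher number from compound 1 to compound 2 (0.32 log units; beyond the scatter) and a 1.1-fold higher number from compound 2 to compound 3 (0.03 log units; within the scatter) only swap one substituted phenyl for another; none removes the whole ring, so no step bears directly on this change. Since the aryl group is lost entirely, a larger step toward weaker inhibition than any seen is expected, roughly a 4.8-fold higher number from compound 3 to compound 4 (0.68 log units; beyond the scatter). Compound 4 is therefore estimated at 400 nM, within 100 nM to 2000 nM.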

Compound 4, half-maximal inhibitory concentration: > 2000 nM
Compound 4 gave a limit, no number; the forecaster's own chance of this, stated with the estimate: 5%; at least 5.0-fold (0.69 log units) between middle value and limit.
By their numbers in this assay, from the lowest: compound 1; then compounds 2 and 3 (each within the scatter of the next). At a limit, above all of these: compound 4.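

In this assay compound 4 gives > 2000 nM, which is a limit of the assay and not a number. Cutting back to a methyl costs far more than any swap of one substituted phenyl for another (an at least 23-fold higher number from compound 3 to compound 4 (1.37 log units; beyond the scatter)) (an at least 25-fold higher number from compound 2 to compound 4 (1.40 log units; beyond the scatter)) (an at least 54-fold higher number from compound 1 to compound 4 (1.73 log units; beyond the scatter)). Inhibition in this series therefore depends on having an aryl ring at this place, not only on which substituent that ring carries.

On these data alone, what remains open is how much of the ring is required. An unsubstituted phenyl, a cyclohexyl ring or a simple propyl chain in its place could show this.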